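Aryl swap on the chalcone arm: solubility

A few compounds are considered here, and "the series" means these few. Any claim that something is new, unique, unknown or untested is made for them only; others in the source may bear on it.

Compound 1 `O=C(CN1CCN(c2cc3c(cc2F)c(=O)c(C(=O)O)cn3C2CC2)CC1)Nc1ccc(C(=O)/C=C/c2ccccc2Cl)cc1` and compound 2 `COc1cc(/C=C/C(=O)c2ccc(NC(=O)CN3CCN(c4cc5c(cc4F)c(=O)c(C(=O)O)cn5C4CC4)CC3)cc2)cc(OC)c1OC` share one core. In a physicochemical assay for solubility, at pH 6.9 (a higher number here means a more soluble compound, a lower number a less soluble compound), compound 1 gives 2.45 ug/mL; compound 2 gives 2.13 ug/mL, the lowest of the two numbers, with a 1.2-fold lower number from compound 1 to compound 2 (0.06 log units; within the scatter). Compound 3 `O=C(CN1CCN(c2cc3c(cc2F)c(=O)c(C(=O)O)cn3C2CC2)CC1)Nc1ccc(C(=O)/C=C/c2cccc([N+](=O)[O-])c2)cc1` carries 3-nitrophenyl in place of 3,4,5-trimethoxyphenyl on a double-bonded chain carbon bound to a double-bonded chain carbon. Within the data shown here, the only step bearing on this is the aryl exchange from compound 1 to compound 2, which stayed within the scatter, so no step beyond the scatter is expected in this assay for compound 3, in either direction: a 1.1-fold higher number from compound 2 to compound 3 (0.03 log units; within the scatter). Compound 3 is therefore estimated at 2.3 ug/mL, within 1 ug/mL to 5.5 ug/mL.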

Compound 3, solubility: 30.7 ug/mL
For compound 3 the middle estimate is 13-fold (1.13 log units) below the measured one, and the stated range ends below it.
By their numbers in this assay, from the lowest: compounds 2 and 1 (each within the scatter of the next); then compound 3.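

In this assay this position is not indifferent to the aryl group: a 14-fold higher number from compound 2 to compound 3 (1.16 log units; beyond the scatter) and a 13-fold higher number from compound 1 to compound 3 (1.10 log units; beyond the scatter) are both large steps beyond the scatter, whereas the exchange of 2-chlorophenyl for 3,4,5-trimethoxyphenyl stayed within it. Among these three compounds, aryl exchange at this carbon therefore does not always leave the number unchanged, and only 3-nitrophenyl stands apart. No measurement at hand accounts for this step.

Still open, on these data alone, is whether the step belongs to 3-nitrophenyl alone, or whether a phenyl ring carrying an amine or a carboxylic acid on the same double-bonded chain carbon would give a similar number.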